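Cytotoxicity on Vero cells: alkynyl chain variations

The compounds below may be only part of what the source reports. "The series", "measured", "known", "first", "only" and "open" are said of these compounds alone.

Three analogues sharing one core have been measured in an ADME assay on Vero cells (Chlorocebus sabaeus) for cytotoxicity, read by MTT assay; a higher number here means that more compound is tolerated, a lower number that less compound is tolerated. Compound 1 `C[Si](C)(C)C#Cc1c[nH]c(=O)[nH]c1=O` gives 270000 nM. Compound 2 `CCCCCCC#Cc1c[nH]c(=O)[nH]c1=O` gives 250000 nM. Compound 3 `O=c1[nH]cc(C#CC2CC2)c(=O)[nH]1` gives 252000 nM, which sits within the scatter of both others, so no order among the three can be read from these numbers. For the measured compounds named here, the one single-point step recorded, a 1.1-fold lower number from compound 1 to compound 3 (0.03 log units; within the scatter), stayed within the scatter.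

Compound 4 `CCCCC#Cc1c[nH]c(=O)[nH]c1=O` is the next member. Relative to compound 3 the change is butyl in place of cyclopropyl on a triple-bonded carbon. Going by the values given here, the only comparable case is compound 2, which carries a longer chain on the same triple-bonded carbon and gives a number indistinguishable from compound 3. The step of a 1.0-fold higher number from compound 3 to compound 4 (0.01 log units; within the scatter) is therefore expected to stay within the scatter. Compound 4 is estimated at 255000 nM, within 150000 nM to 400000 nM.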

Compound 4, half-maximal cytotoxic concentration: 253000 nM
Beside the measured number, compound 4's estimate is 1.0-fold (0.00 log units) above it, and the stated range covers the measured number.
By their numbers in this assay, from the lowest: compounds 2, 3, 4 and 1 (each within the scatter of the next).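

In this assay, butyl in place of cyclopropyl on a triple-bonded carbon leaves the number unmoved (a 1.0-fold higher number from compound 3 to compound 4 (0.00 log units; within the scatter)), so the ring on this carbon can go without a readable change. Shortening the chain (a 1.0-fold higher number from compound 2 to compound 4 (0.01 log units; within the scatter)) and replacing the silicon-bearing group with the all-carbon butyl (a 1.1-fold lower number from compound 1 to compound 4 (0.03 log units; within the scatter)) are equally unreadable. No evidence bears on why these numbers coincide.

As far as these compounds go, whether a group carrying an amine or a carboxylic acid on the triple-bonded carbon would move the number remains open. The same holds for a phenyl ring there.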